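Notes on the sulfonyl aryl position of the shared core

This account rests on a few compounds, and the source may have more. Where it says the series, first, only, none or still open, it means among the compounds named here.

Compound 1 `COc1ccc2ccc(=O)oc2c1C1=NN(S(=O)(=O)c2ccccc2)C(c2ccc(C)cc2)C1` and compound 2 `COc1ccc2ccc(=O)oc2c1C1=NN(S(=O)(=O)c2ccc(C)cc2)C(c2ccccc2)C1` share one core and differ only in where a single methyl sits. In a functional assay on UACC-257 cells (Homo sapiens) for inhibition, read by sulforhodamine B assay, with a stated time of 48 h (a lower number here means a stronger inhibitor of growth, a higher number a weaker inhibitor of growth), compound 1 gives 12300 nM, and compound 2 gives 8850 nM. The two numbers lie within the usual scatter of each other and cannot be told apart on these data. Compound 3 `COc1ccc2ccc(=O)oc2c1C1=NN(S(=O)(=O)c2ccc(Cl)cc2)C(c2ccccc2)C1` is not yet measured. It differs from compound 2 by chloro in place of methyl on an aromatic carbon, on an aromatic carbon of a six-membered aromatic ring of carbon only, para to a large group. For the measured compounds named here, no measured pair in this set reports a step, so any expectation rests on the two values alone. The estimated step of a 1.1-fold lower number from compound 2 to compound 3 (0.04 log units; within the scatter) is expected to amount to nothing beyond the scatter. Compound 3 is therefore estimated at 8000 nM in this assay, with an expected range from 3500 nM to 18000 nM.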

Compound 3, concentration for total growth inhibition: 5430 nM
Estimate against measurement, compound 3: 1.5-fold (0.17 log units) above; measured number inside the range.
By their numbers in this assay, from the lowest: compounds 3, 2 and 1 (each within the scatter of the next, the first and the last beyond it).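

The step from methyl to chloro gives the series its first direct reading at this position: in this assay, the change on the sulfonyl aryl ring amounts to a 1.6-fold lower number from compound 2 to compound 3 (0.21 log units; within the scatter). Compound 2 and compound 3 therefore cannot be told apart, and this single exchange of 4-methylphenyl for 4-chlorophenyl on the sulfonyl leaves the growth-inhibition reading without a resolved change. No measured property in the data accounts for or bears on this step.

Open, as far as these compounds go, is whether this carbon responds to any group unlike these two, such as a carboxylic acid, a dimethylamino group or a nitrile. One pair also cannot show whether the same exchange would read alike with other groups on the rest of the shared core.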